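A Pyrrolidine Amide Set Against a Toxicity Limit

The compounds below may be only part of what the source reports. "The series", "measured", "known", "first", "only" and "open" are said of these compounds alone.

In an ADME assay on Vero cells (Chlorocebus sabaeus) for cytotoxicity (on this read-out lower numbers stand for higher toxicity in this test and higher numbers for lower toxicity in this test), two compounds have been run so far. Compound 1 `C#C[C@@]1(O)[C@H](O)[C@@H](CO)O[C@H]1n1ccc(N)nc1=O` returned only a limit, > 100000 nM, not a number. Compound 2 `O=C(O)CCC(=O)Nc1ccc(-c2nc3cc(C(F)(F)F)ccc3[nH]2)cc1` likewise returned only a limit, > 100000 nM, in the same test. For the measured compounds named here, both results sit at the limit of > 100000 nM in this assay, at which 2 of the 2 values shown sit, so compound 2 stands at the edge of what this assay can report, with no measured value anywhere below it and no step between measured compounds to guide a prediction.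

Compound 3 `O=C(CN1CCCC1)Nc1ccc(-c2nc3cc(C(F)(F)F)ccc3[nH]2)cc1` differs from compound 2 in one place: pyrrolidin-1-yl in place of carboxymethyl on a saturated chain carbon bound to a carbonyl carbon.

With nothing measured but limits, the expected step in this assay is one of none beyond the scatter, an at least 1.1-fold lower number from compound 2 to compound 3 (0.04 log units; that floor lies within the scatter), though a move into the numbered range cannot be excluded. Compound 3 is therefore estimated at 90000 nM in this assay, within a range from 20000 nM to 300000 nM.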

Compound 3, half-maximal cytotoxic concentration: > 100000 nM
Compound 3: only a limit was reported; the forecaster's own chance of this, stated with the estimate: 55%; middle value at least 1.1-fold (0.04 log units) away from the limit.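

In this assay compound 3 gives > 100000 nM, which is a limit and not a number. The step from compound 2 to compound 3 therefore cannot be read: the limit of > 100000 nM in this assay, at which 3 of the 3 values shown sit.

The compounds shown leave open what change, if any, would bring a numbered value in this assay.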